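The compounds below may be only part of what the source reports. "The series", "measured", "known", "first", "only" and "open" are said of these compounds alone.

Compound 1 `CO[C@H]1CC[C@H](NC(=O)c2n[nH]cc2NC(=O)c2cnc3ccccn23)CC1` is the reference for this account. In an ADME assay on MRC5 cells (Homo sapiens) for inhibition, with a stated time of 72 h (a higher number here means that more compound is needed for the effect, a lower number that less compound is needed), compound 1 gives 5900 nM, the lowest of the two numbers available, so less of it is needed for the effect than of any measured neighbour. Compound 3 `CO[C@H]1CC[C@H](NC(=O)c2n[nH]cc2NC(=O)c2c(C)nc3ccccn23)CC1` gives 34000 nM in this assay, and the step of a 5.8-fold higher number from compound 1 to compound 3 (0.76 log units; beyond the scatter) is beyond the scatter. Compound 2 `COCCNC(=O)c1n[nH]cc1NC(=O)c1c(OC)cccc1OC` reaches only a limit of this assay, > 50000 nM, rather than a number. (the limit of > 50000 nM in this assay, at which 1 of the 3 values shown sits).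

Compound 4 `CO[C@H]1CC[C@H](NC(=O)c2n[nH]cc2NC(=O)c2ccccc2)CC1` differs from compound 1 in one place: a group of 6 heavy atoms (6 carbon; one six-membered aromatic ring of carbon only) in place of a group of 9 heavy atoms (7 carbon, 2 nitrogen; one five-membered aromatic ring with 2 hetero atoms, one six-membered aromatic ring with 1 hetero atom), on a carbonyl carbon. Going by the values given here, the single measured step, from compound 1 to compound 3, shows that even a small change on this side of the shared core raised the number modestly; the exchange in compound 4 is larger, and a rise of at least similar size is expected, with a fair chance of reaching the limit.

The step of a 5.1-fold higher number from compound 1 to compound 4 (0.71 log units; beyond the scatter) is the expected outcome. Compound 4 is estimated at 30000 nM, within a range of 8000 nM to 50000 nM.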

Compound 4, half-maximal effective concentration: 800 nM
For compound 4 the middle estimate is 38-fold (1.57 log units) above the measured one; measured number below the stated range.
By their numbers in this assay, from the lowest: compound 4; then compound 1; then compound 3. At a limit, above all of these: compound 2.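

The exchange of the two-ring group for phenyl, on a carbonyl carbon whose other neighbour is an amide-type nitrogen, gives a 7.4-fold lower number from compound 1 to compound 4 (0.87 log units; beyond the scatter) in this assay. Going by these compounds alone, the only earlier step at this side of the shared core went the other way, a 5.8-fold higher number from compound 1 to compound 3 (0.76 log units; beyond the scatter), so changes here can move the number in either direction, and the two-ring group of compound 1 is not required for the effect. Nothing measured among these compounds gives a reason for the lower number of compound 4.

Going by these compounds, it remains open how a pyridine ring in place of phenyl, or a chlorine or an amine on the phenyl ring, would move the number. Compound 4 differs from compound 2 in more than one place, so compound 2 does not bear on this change. Compound 2 gives only a limit, > 50000 nM.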